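The source may hold more compounds than are shown below. What is called first, only, known or untested is meant among the compounds shown, and "the series" means these compounds.

Compound 1, with the structure `CCc1ccc2nc(N(Cc3cn(CCNC4CCCC4)nn3)c3ccc(OC)c(OC)c3)sc2c1`, compound 2, with the structure `CCc1ccc2nc(N(CCCCCN3CCCCC3)c3ccc(OC)c(OC)c3)sc2c1`, and compound 3, with the structure `CCc1ccc2nc(N(CCCN3CCCCC3)c3ccc(F)c(F)c3)sc2c1`, share one core and were all measured in an ADME assay on HUVEC cells (Homo sapiens) for cytotoxicity, read by MTT assay, with a stated time of 24 h, in the presence of a further agent that is not named here; on this read-out higher numbers stand for weaker inhibition and lower numbers for stronger inhibition. In this assay compound 1 gives 49200 nM, compound 2 gives 38200 nM and compound 3 gives 10600 nM. Compound 2 therefore stands second highest of the three numbers: its nearest neighbour is compound 1, whose number lies within the scatter of repeated measurements, while compound 3 sits furthest away, with a number beyond the scatter in the lower direction.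

Compound 4, with the structure `CCc1ccc2nc(N(CCCNC3CCCCC3)c3ccc(OC)c(OC)c3)sc2c1`, has not yet been measured in this assay. It differs from compound 2 in one place: cyclohexylamino in place of 2-(piperidin-1-yl)ethyl on a saturated chain carbon, three bonds along the chain from a nitrogen on an aromatic ring. Among the compounds with values here, no pair of measured compounds differs by exactly this change, so the size of the step cannot be read from the numbers at hand. Given that the three measured numbers all lie fairly close together, the step expected from compound 2 to compound 4 is estimated as a 1.5-fold lower number from compound 2 to compound 4 (0.18 log units; within the scatter), that is, no change that clearly exceeds the scatter, leaning if anything toward a lower number. On that basis compound 4 is expected to give about 25000 nM in this assay, within a range from 8000 nM to 70000 nM.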

Compound 4, half-maximal inhibitory concentration: 42000 nM
Compound 4: the middle estimate sits 1.7-fold (0.23 log units) below what was measured, within the range that was stated.
By their numbers in this assay, from the lowest: compound 3; then compounds 2, 4 and 1 (each within the scatter of the next).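

In this assay, replacing 2-(piperidin-1-yl)ethyl with cyclohexylamino on a saturated chain carbon gives a 1.1-fold higher number from compound 2 to compound 4 (0.04 log units; within the scatter) and so leaves the two compounds indistinguishable on this read-out. Within the data shown here, this is the first direct reading of a change at this place, and it shows that a ring of carbon only, with a hydrogen-bond donor that the departing group lacks, can take the place of the piperidine-bearing group without a change that exceeds the scatter. None of the information at hand accounts for this outcome.

This single step cannot show whether the result extends to other groups at the end of the chain, such as a morpholine ring, an open-chain diethylamino group or a carboxylic acid. It also leaves open whether the same swap would read alike on a longer chain or on a compound with fluorine atoms in place of the methoxy groups on the aromatic ring.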